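This account rests on a few compounds, and the source may have more. Where it says the series, first, only, none or still open, it means among the compounds named here.

In a functional assay on DU-145 cells (Homo sapiens) for cytotoxicity, read by MTT assay (a lower number here means a stronger inhibitor, a higher number a weaker inhibitor), compound 2 `C[C@H](NC(=S)Nc1cc(C(F)(F)F)cc(C(F)(F)F)c1)c1nc2ccccc2[nH]1` gives 154000 nM, the highest of the three numbers measured. Its nearest neighbour is compound 1 `CC(C)[C@H](NC(=S)Nc1cc(C(F)(F)F)cc(C(F)(F)F)c1)c1nc2ccccc2[nH]1`, which gives 26100 nM; the step of a 5.9-fold higher number from compound 1 to compound 2 (0.77 log units; beyond the scatter) arises from methyl in place of isopropyl on a saturated chain carbon bound to an amide-type nitrogen and an aromatic carbon. Compound 3 `CC(C)[C@@H](NC(=S)NCc1ccccc1)c1nc2ccccc2[nH]1` gives 17300 nM, the lowest of the three. Compound 4 `C[C@@H](NC(=S)Nc1cc(C(F)(F)F)cc(C(F)(F)F)c1)c1nc2ccccc2[nH]1` differs from compound 2 as follows: the two compounds have the same atoms and bonds and differ only in configuration as drawn: 1 of 1 stereo elements differ; a stereocentre at a saturated chain carbon is drawn S in compound 2 and R in compound 4. Going by the values given here, none of the measured steps concerns configuration at that carbon; the only step in this set, a 5.9-fold higher number from compound 1 to compound 2 (0.77 log units; beyond the scatter), changes the size of the group on the carbon and so offers no guide to a change drawn purely in stereochemistry. Among the compounds with values here, with no measured precedent, the expected step of no change at the digits printed from compound 2 to compound 4 (within the scatter) is not set beyond the scatter in either direction, and the uncertainty around it is wide. Compound 4 is accordingly estimated at 154000 nM in this assay, within a range from 40000 nM to 600000 nM.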

Compound 4, half-maximal inhibitory concentration: 17600 nM
For compound 4 the middle estimate is 8.8-fold (0.94 log units) above the measured one; the measured number lies below the stated range.
By their numbers in this assay, from the lowest: compounds 3, 4 and 1 (each within the scatter of the next); then compound 2.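

Configuration at this saturated chain carbon proves to matter in this assay: with the methyl group and the rest of the structure held constant, there is an 8.8-fold lower number from compound 2 to compound 4 (0.94 log units; beyond the scatter), on going from the carbon drawn S to the carbon drawn R. The earlier step changed only the group on this carbon, so this is the first evidence in the set that its spatial arrangement alone can shift the number beyond the scatter. The step can be assigned to that single structural difference, with no other change to share it: the fact that compounds 2 and 4 differ only in the configuration as drawn.

The compounds shown leave open whether the R-over-S ordering seen with methyl also holds with isopropyl on this carbon. They also leave open how a longer chain or an aminomethyl group would behave there in either configuration.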